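Chloro in Place of Trifluoromethyl: An Expected Cytotoxicity Value

The source may hold more compounds than are shown below. What is called first, only, known or untested is meant among the compounds shown, and "the series" means these compounds.

Compound 1 `O=C(Nc1cc(C(F)(F)F)ccc1C(F)(F)F)c1cc(Cl)ccc1O` and compound 2 `O=C(Nc1cc(C(F)(F)F)ccc1Cl)c1cc(Cl)ccc1O` share a core. In an ADME assay on cells (Macrophage, Mus musculus) for cytotoxicity, read by resazurin assay, with a stated time of 3 days (a lower number here means a stronger inhibitor, a higher number a weaker inhibitor), compound 1 gives 6600 nM and compound 2 gives 3500 nM. The two differ by chloro in place of trifluoromethyl on an aromatic carbon, and the step is a 1.9-fold lower number from compound 1 to compound 2 (0.28 log units; within the scatter). Compound 3 `O=C(Nc1ccc(F)c(C(F)(F)F)c1)c1cc(Cl)ccc1O` gives 5300 nM in this assay; the difference between its core and that of compound 1 is not broken down here. Compound 4 `O=C(Nc1ccc(F)c(Cl)c1)c1cc(Cl)ccc1O` differs from compound 3 by chloro in place of trifluoromethyl on an aromatic carbon, the same kind of change, though here the place lies ortho to a fluoro group and meta to a large group rather than ortho to a large group and para to a trifluoromethyl group. Because the earlier step of a 1.9-fold lower number from compound 1 to compound 2 (0.28 log units; within the scatter) lay within the scatter, compound 4 is expected to show a step of a 1.3-fold lower number from compound 3 to compound 4 (0.12 log units; within the scatter) and a value estimated near 4000 nM.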

Compound 4, half-maximal inhibitory concentration: 4400 nM
The estimate for compound 4 lay 1.1-fold (0.04 log units) below the measured number, and the stated range covers the measured number.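

Setting chloro in place of trifluoromethyl on the core of compound 3 gives a 1.2-fold lower number from compound 3 to compound 4 (0.08 log units; within the scatter) in this assay, and the two cores cannot be told apart on this change: the same change on two cores in this assay, a 1.9-fold lower number (0.28 log units; within the scatter) from compound 1 to compound 2 and a 1.2-fold lower number (0.08 log units; within the scatter) from compound 3 to compound 4, 1.6-fold (0.19 log units) apart, within the scatter of two such steps. So, in this small set, the change carries from one core to the other without a detectable difference in its step. It does not show that the change itself moves the number on either core, since each step lies within the scatter, and two cores cannot speak for the whole series.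

The compounds shown leave open how an amine or a carboxylic acid would read in this assay in place of the trifluoromethyl. They also leave open whether the step stays this small on other cores.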